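The source may hold more compounds than are shown below. What is called first, only, known or untested is meant among the compounds shown, and "the series" means these compounds.

Measured compounds: compound 1 `COc1cc(C(c2ccc(O)c(OC)c2)[C@H](CF)C(C)C)ccc1O` with 19000 nM in a functional assay on HL-60 cells (Homo sapiens) for cytotoxicity, read by WST assay, with a stated time of 48 h; on this read-out lower numbers stand for stronger inhibition and higher numbers for weaker inhibition; compound 2 `COC[C@@H](C(C)C)C(c1ccc(O)c(OC)c1)c1ccc(O)c(OC)c1` with 54000 nM in this assay.

Within the data shown here, compound 2 gives the highest of the two numbers seen so far, which means it is the weaker of the two, and its only neighbour is compound 1 at a 2.8-fold higher number from compound 1 to compound 2 (0.45 log units; beyond the scatter). Compound 3 `COc1cc(C(c2ccc(O)c(OC)c2)[C@H](C)[C@@H](C)CO)ccc1O` has not been measured yet. It differs from compound 2 in one place: 2-(hydroxymethyl)-1-methylpropyl in place of 1-(methoxymethyl)-2-methylpropyl on a saturated chain carbon bound to two aromatic carbons. Among the measured compounds shown here, the single measured step that touches the same position, the change from compound 1 to compound 2, raised the number by a modest amount that lies beyond the usual scatter, so a change at this carbon can move the read-out, but the two compounds give no direct guide for swapping a methoxymethyl for a hydroxymethyl while also rearranging the methyl groups. The expectation is therefore cautious: a step of a 1.4-fold lower number from compound 2 to compound 3 (0.13 log units; within the scatter), which in practice is no clear movement beyond the scatter. Compound 3 is estimated at 40000 nM, with a range from 12000 nM to 130000 nM.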

Compound 3, half-maximal inhibitory concentration: > 100000 nM
Compound 3 gave a limit, no number; the forecaster's own chance of this, stated with the estimate: 25%; middle value at least 2.5-fold (0.39 log units) away from the limit.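

In this assay compound 3 gives only a limit of the assay and not a number: the limit of > 100000 nM in this assay, at which 1 of the 3 values shown sits.

Measured against the 1-(fluoromethyl)-2-methylpropyl group, the 2-(hydroxymethyl)-1-methylpropyl group brings a clear loss of activity, with an at least 5.2-fold higher number from compound 1 to compound 3 (0.72 log units; beyond the scatter), so the group on this saturated chain carbon can weaken the read-out well beyond the scatter. Measured against the 1-(methoxymethyl)-2-methylpropyl group, the picture is less firm, with an at least 1.8-fold higher number from compound 2 to compound 3 (0.26 log units; that floor lies within the scatter), which means that the real gap may or may not exceed the scatter, and only its lower bound is known.

The limit leaves open how weak compound 3 really is, and since the hydroxymethyl end and the rearranged methyl groups enter together, the compounds shown cannot separate what each of them contributes. From the compounds shown here alone, how an amine or a carboxylic acid at the end of this branch, or a longer chain in its place, would read in this assay also remains open.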